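Phenyl for dichlorophenyl on the ring amine nitrogen

A few compounds are considered here, and "the series" means these few. Any claim that something is new, unique, unknown or untested is made for them only; others in the source may bear on it.

Measured so far:
compound 1 `Cc1nc(-c2ccccc2)c(C(=O)N2CCN(c3cccc(Cl)c3Cl)CC2)o1`: 133 nM
compound 2 `CC(C)(C)c1nc(-c2ccccc2F)c(C(=O)N2CCN(c3cccc(Cl)c3)CC2)o1`: > 1000 nM

Among the measured compounds shown here, compound 1 is the only compound with a number in a functional assay on HL-60 cells (Homo sapiens) for inhibition, read by MTT assay, with a stated time of 72 h; on this read-out higher numbers stand for weaker inhibition and lower numbers for stronger inhibition; there compound 1 gives 133 nM. Compound 2 in this assay reaches only a limit of the assay, > 1000 nM, which is the limit of > 1000 nM in this assay, at which 1 of the 2 values shown sits. For the measured compounds named here, no step between compounds that differ in one place is available: compound 1 and compound 2 differ at several places at once, so their two values show only that one is a number and the other a limit.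

Compound 3 `Cc1nc(-c2ccccc2)c(C(=O)N2CCN(c3ccccc3)CC2)o1` has not been measured. It differs from compound 1 in one place: phenyl in place of 2,3-dichlorophenyl on an amine nitrogen in a ring. The chlorine substituents leave and the remainder of the core of compound 1 stays. Going by the values given here, with no one-place step measured, the size of the effect rests on no direct comparison. The expected step is a 3.0-fold higher number from compound 1 to compound 3 (0.48 log units; beyond the scatter), toward weaker inhibition and beyond the usual scatter. Compound 3 is thus expected near 400 nM, with a range from 120 nM to 1500 nM. A limit rather than a number is possible.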

Compound 3, half-maximal inhibitory concentration: 39.1 nM
Beside the measured number, compound 3's estimate is 10-fold (1.01 log units) above it; the whole stated range lies above it.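

In this assay, among the compounds shown here, phenyl in place of 2,3-dichlorophenyl on the amine nitrogen in the ring gives a 3.4-fold lower number from compound 1 to compound 3 (0.53 log units; beyond the scatter), the first change at a single place that can be read. The position therefore accepts an unsubstituted phenyl, and on the core of compound 1 inhibition does not depend on the two chlorine substituents; here, losing them goes with stronger inhibition, by a modest step beyond the scatter. The values shown give no account of why the number falls, and no measured property of either group bears on this step.

Still open, from the compounds shown here alone, is how a single chlorine on this same core would compare with the unsubstituted phenyl and the 2,3-dichlorophenyl, and whether the step carries over to cores with other groups. Also open, going by these compounds, is whether a methoxy group or a nitrile on the phenyl, or a cyclohexyl group in its place on the ring nitrogen, would retain the inhibition seen with compound 3.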